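A few compounds are considered here, and "the series" means these few. Any claim that something is new, unique, unknown or untested is made for them only; others in the source may bear on it.

Three compounds of the series have numbers in a functional assay on HUVEC cells (Homo sapiens) for inhibition, with a stated time of 4 days; on this read-out lower numbers stand for stronger inhibition and higher numbers for weaker inhibition. Compound 1 `COc1ccc(C(N)=O)cc1COc1ccc(Cl)cc1` gives 660 nM in this assay. Compound 2 `COc1ccc(C#N)cc1COc1ccc(Cl)c(C)c1` gives 1500 nM. Compound 3 `COc1ccc(C(N)=O)cc1/C=C/c1ccc(Cl)cc1` gives 87 nM, the lowest of the three numbers; the nearest of the others is compound 1 and the furthest is compound 2, and both gaps lie beyond the scatter. No two of the measured compounds differ in one place only, so no single step is shown among them.

Compound 4 `COc1ccc(/C=C/c2cc(C(N)=O)ccc2OC)cc1` has not been measured. It differs from compound 3 in one place: methoxy in place of chloro on an aromatic carbon. The change sits on an aromatic carbon of a six-membered aromatic ring of carbon only, para to a large group. The measured compounds give no direct reading on this exchange, since each differs from the others in more than one feature at once. A step toward a higher number is expected, a 2.3-fold higher number from compound 3 to compound 4 (0.36 log units; beyond the scatter), of a size close to the edge of the scatter. In this assay compound 4 is expected to give about 200 nM, with a range from 50 nM to 800 nM.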

Compound 4, half-maximal inhibitory concentration: 8800 nM
Compound 4: the middle estimate sits 44-fold (1.64 log units) below what was measured; the measured number lies above the stated range.
By their numbers in this assay, from the lowest: compound 3; then compound 1; then compound 2; then compound 4.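

In this assay, methoxy in place of chloro on this aromatic carbon, para to a large group, gives a 100-fold higher number from compound 3 to compound 4 (2.00 log units; beyond the scatter), so this position is far from indifferent to the group it carries. Among these compounds, this is the first single-place reading, as the earlier compounds differ from one another in more than one feature and could not isolate the chloro. The comparison favours chloro over methoxy on this one pair only, and nothing on hand bears on why the gap is so large.

As far as these compounds go, it remains open where fluoro, an amine or a longer chain such as ethoxy would fall at this position relative to chloro and methoxy. Also open, from the compounds shown here alone, is whether the same exchange gives a step of similar size on the core of compound 1.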